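A few compounds are considered here, and "the series" means these few. Any claim that something is new, unique, unknown or untested is made for them only; others in the source may bear on it.

Compound 3 `NC1=NC2(CCOCC2)N(OCCCOc2ccccc2Br)C(N)=N1` is one of a set sharing the core of compound 1 `NC1=NC2(CCOCC2)N(OCCCOc2ccc(Cl)c(Cl)c2)C(N)=N1`. In a functional assay on HepG2 cells (Homo sapiens) for antiproliferative activity, read by MTT assay, with a stated time of 72 h (on this read-out lower numbers stand for stronger inhibition and higher numbers for weaker inhibition), compound 3 gives 860 nM. Among the measured compounds shown here, of the two numbers so far it stands highest: the only measured step, a 2.3-fold higher number from compound 1 to compound 3 (0.35 log units; beyond the scatter), describes its gap to compound 1, which gives 380 nM in this assay. Compound 2 `NC1=NC2(CCOCC2)N(OCCCOc2ccc(F)cc2)C(N)=N1` is reported in this assay as "not determined" (no result reported). Compound 4 `Cc1cc(C)cc(OCCCON2C(N)=NC(N)=NC23CCOCC3)c1` changes the aryl group again: 3,5-dimethylphenyl in place of 2-bromophenyl on an oxygen on a saturated carbon. For the measured compounds named here, the one step that bears on it, a 2.3-fold higher number from compound 1 to compound 3 (0.35 log units; beyond the scatter), is modest, so a change to another substituted phenyl is expected to move this assay little, likely within the scatter or a small step either way. Compound 4 is therefore estimated at 700 nM, with a range from 250 nM to 2500 nM, an expected step of a 1.2-fold lower number from compound 3 to compound 4 (0.09 log units; within the scatter).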

Compound 4, half-maximal inhibitory concentration: 680 nM
Compound 4: middle estimate off by 1.0-fold (0.01 log units), on the high side, within the range that was stated.
By their numbers in this assay, from the lowest: compounds 1, 4 and 3 (each within the scatter of the next, the first and the last beyond it).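

In this assay the 3,5-dimethylphenyl group in place of 2-bromophenyl gives a 1.3-fold lower number from compound 3 to compound 4 (0.10 log units; within the scatter) and in place of 3,4-dichlorophenyl gives a 1.8-fold higher number from compound 1 to compound 4 (0.25 log units; within the scatter) on the same oxygen on a saturated carbon. An aryl group of carbon only, without halogen, thus sits within the scatter of both halogen-bearing compounds, though those two differ beyond it (a 2.3-fold higher number from compound 1 to compound 3 (0.35 log units; beyond the scatter)). Nothing given here explains this result. The compounds shown leave open how an aryl group bearing an amine or a carboxylic acid would behave in this assay. They also leave open what a longer chain on this oxygen would do.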